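Replacing Diethylamino with 4-(Oxetan-3-yl)piperazin-1-yl

A few compounds are considered here, and "the series" means these few. Any claim that something is new, unique, unknown or untested is made for them only; others in the source may bear on it.

- Compound 1 `CCN1C(=O)COc2c(CN3CCCCC3)cc(Nc3ncc(F)c(-c4ccc(F)cc4OC)n3)cc21` gives 50 nM in a functional assay on MV4-11 cells (Homo sapiens) for inhibition, read by luminescence, with a stated time of 72 h; a higher number here means a weaker inhibitor, a lower number a stronger inhibitor
- Compound 2 `CCN(CC)Cc1cc(Nc2ncc(F)c(-c3ccc(F)cc3OC)n2)cc2c1OCC(=O)N2CC` gives 26 nM in this assay

Compound 2 stands level with compound 1 in this assay, as their two values lie within the scatter of each other. The next compound, compound 3 `CCN1C(=O)COc2c(CN3CCN(C4COC4)CC3)cc(Nc3ncc(F)c(-c4ccc(F)cc4OC)n3)cc21`, keeps the core of compound 2 but differs as follows: 4-(oxetan-3-yl)piperazin-1-yl in place of diethylamino on a saturated chain carbon bound to an aromatic carbon, with 4-(oxetan-3-yl)piperazin-1-yl in place of diethylamino on a saturated chain carbon bound to an aromatic carbon.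

For the measured compounds named here, only one measured step bears on this change. It is a 1.9-fold lower number from compound 1 to compound 2 (0.28 log units; within the scatter), which exchanges piperidin-1-yl for diethylamino at the same place and stays within the scatter. Neither measured compound carries the entering group, so this single step offers limited guidance. No shift beyond the scatter is therefore expected, and the range is kept wide in both directions. The estimated change is a 1.5-fold higher number from compound 2 to compound 3 (0.19 log units; within the scatter) and is expected to remain small. For compound 3 the expected value is 40 nM, with an estimated range from 13 nM to 125 nM in this measurement.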

Compound 3, half-maximal inhibitory concentration: 105 nM
Compound 3: middle estimate off by 2.6-fold (0.42 log units), on the low side, and the stated range covers the measured number.
By their numbers in this assay, from the lowest: compounds 2 and 1 (each within the scatter of the next); then compound 3.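

Compounds 1 and 2 had shown only that one open or ring-closed amine on a saturated chain carbon bound to an aromatic carbon can stand in for the other within the scatter in this assay. This change goes beyond the scatter against both of them, measured from the diethylamino compound (a 4.0-fold higher number from compound 2 to compound 3 (0.61 log units; beyond the scatter)) and from the piperidin-1-yl compound (a 2.1-fold higher number from compound 1 to compound 3 (0.32 log units; beyond the scatter)), so the group at this place does affect the number, although both steps remain modest and compound 3 retains inhibition in the nanomolar range (105 nM). No measurement at hand explains why the 4-(oxetan-3-yl)piperazin-1-yl group shifts the number in this direction.

The compounds shown leave open whether the shift goes with the piperazine ring or with the oxetane carried on it, since the whole group enters in a single exchange. A 4-methylpiperazin-1-yl group or a morpholin-4-yl group at the same place would help to separate these two parts and show whether the shift is tied to the oxetane.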